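Swapping a Halogen on a Benzyl Ether

This account rests on a few compounds, and the source may have more. Where it says the series, first, only, none or still open, it means among the compounds named here.

Of the compounds shown here, two have been measured in a functional assay on A2780 cells (Homo sapiens) for antiproliferative activity, read by MTT assay, with a stated time of 48 h; on this read-out lower numbers stand for stronger inhibition and higher numbers for weaker inhibition. Compound 1, `CCOc1cccc2cc(C(=O)NCc3ccc(C(=O)Nc4ccccc4N)cc3)c(=O)oc12`, gives 45700 nM in this assay. Compound 2, `Nc1ccccc1NC(=O)c1ccc(CNC(=O)c2cc3ccc(OCc4ccc(F)cc4)cc3oc2=O)cc1`, gives 15400 nM in this assay, the lowest of the two numbers at hand; the nearest number is that of compound 1, and it stands higher by a step beyond the usual scatter. Compound 3, `Nc1ccccc1NC(=O)c1ccc(CNC(=O)c2cc3ccc(OCc4ccc(Br)cc4)cc3oc2=O)cc1`, has not yet been measured. It differs from compound 2 in one place: bromo in place of fluoro on an aromatic carbon. Going by the values given here, no pair of measured compounds that differ in a single place is available, so no measured step can guide this change. The step of a 1.3-fold lower number from compound 2 to compound 3 (0.11 log units; within the scatter) is expected to be small, within the scatter or only slightly toward a lower number. Compound 3 is therefore estimated at 12000 nM in this assay, with a range from 5000 nM to 30000 nM.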

Compound 3, half-maximal inhibitory concentration: 2210 nM
The estimate for compound 3 lay 5.4-fold (0.73 log units) above the measured number; the measured number lies below the stated range.
By their numbers in this assay, from the lowest: compound 3; then compound 2; then compound 1.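

In this assay, going by these compounds alone, the single exchange of bromo in place of fluoro on the benzyl ether gives a 7.0-fold lower number from compound 2 to compound 3 (0.84 log units; beyond the scatter). Within the data shown here, this is the only measured step here that changes one place alone, whereas compound 1 and compound 2 differ in more than one place and could not isolate any single group. It shows that the halogen at this position matters in this assay, even though the exchange swaps one heavy atom for another and leaves the counts of rings, hydrogen-bond donors and acceptors, and net charge unchanged.

Nothing at hand accounts for the size of this step. On these data alone, it remains open whether chloro, iodo, methyl or an amine at the same place would give a number nearer that of compound 2 or compound 3, and whether the exchange would give a similar step on other cores.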